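The compounds below may be only part of what the source reports. "The series", "measured", "known", "first", "only" and "open" are said of these compounds alone.

Working notes on the series. Compound 1 `CN(C)C(=O)C[C@H](CSc1ccccc1)Nc1c(C(=O)N/N=C/c2ccccc2F)cnc2c(C(F)(F)F)cccc12` in an ADME assay on Vero cells (Chlorocebus sabaeus) for cytotoxicity, read by MTT assay, with a stated time of 72 h (a lower number here means a stronger inhibitor, a higher number a weaker inhibitor), gives only a limit of the assay, > 62.5 ug/mL, which is the limit of > 62.5 ug/mL in this assay, at which 1 of the 2 values shown sits. Compound 2 `COc1ccc(/C=N/NC(=O)c2cnc3c(C(F)(F)F)cccc3c2N[C@@H](CSc2ccccc2)CC(=O)N(C)C)cc1` in this assay stands at "not determined" (no result reported), so no number places it among the values shown. Compound 3 `CN(C)C(=O)C[C@H](CSc1ccccc1)Nc1c(C(=O)N/N=C/c2ccc(F)cc2)cnc2c(C(F)(F)F)cccc12` is unmeasured in this assay and differs from compound 2 by fluoro in place of methoxy on an aromatic carbon. With no measured step shown for this change, no direction and no size beyond the scatter can be stated. For compound 3 in this assay the expected value is 62.5 ug/mL, with a range from 30 ug/mL to 120 ug/mL, the result most likely to be reported as a limit.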

Compound 3, half-maximal inhibitory concentration: > 62.5 ug/mL
Compound 3 ended at the assay's limit; the forecaster's own chance of this, stated with the estimate: 70%; the middle value sits exactly at the limit.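

No new step can be read from compound 1 to compound 3 in this assay, because both results are limits of the assay: the limit of > 62.5 ug/mL in this assay, at which 2 of the 3 values shown sit.

Going by these compounds, whether 2-fluorophenyl and 4-fluorophenyl differ at all in this assay stays open.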